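From Difluorophenyl to Pyridinylethyl: an Expected Step

This account rests on a few compounds, and the source may have more. Where it says the series, first, only, none or still open, it means among the compounds named here.

Compound 1 `FC(F)(F)Oc1ccc(Cn2cc(CCCOc3cccc4cccnc34)nn2)cc1`: 5 ug/mL in a functional assay on PC-3 cells (Homo sapiens) for inhibition, read by sulforhodamine B assay, with a stated time of 48 h; on this read-out higher numbers stand for weaker inhibition of growth and lower numbers for stronger inhibition of growth
Compound 2 `Fc1ccc(Cn2cc(CCCOc3cccc4cccnc34)nn2)cc1F`: 6.6 ug/mL
Compound 3 `c1ccc(Cn2cc(CCCOc3cccc4cccnc34)nn2)cc1`: 16.8 ug/mL

Among these three, compound 2 lies within the usual scatter of compound 1 and gives a clearly lower number than compound 3. Compound 4 `c1cncc(CCCn2cc(CCCOc3cccc4cccnc34)nn2)c1` differs from compound 2 by 2-(pyridin-3-yl)ethyl in place of 3,4-difluorophenyl on a saturated chain carbon bound to an aromatic nitrogen. Going by the values given here, no measured step exchanges a carbon-only ring for one holding a nitrogen, nor lengthens the linker; the closest guide is a 2.5-fold higher number from compound 2 to compound 3 (0.41 log units; beyond the scatter), and a 3.4-fold higher number from compound 1 to compound 3 (0.53 log units; beyond the scatter) also showed a higher number once a substituent left that ring. Because a 2.5-fold higher number from compound 2 to compound 3 (0.41 log units; beyond the scatter) followed the loss of both fluorines, and the entering group carries none, a modest rise is expected. Compound 4 is therefore estimated at 15 ug/mL, with a likely range from 5 ug/mL to 45 ug/mL. Against compound 2 the expected step for compound 4 is a 2.3-fold higher number from compound 2 to compound 4 (0.36 log units; beyond the scatter).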

Compound 4, concentration for 50% growth inhibition: 26.7 ug/mL
Estimate against measurement, compound 4: 1.8-fold (0.25 log units) below; low and high end bracket the measured number.
By their numbers in this assay, from the lowest: compounds 1 and 2 (each within the scatter of the next); then compounds 3 and 4 (each within the scatter of the next).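

At this place, on a saturated chain carbon bound to an aromatic nitrogen, a ring holding nitrogen and a longer chain enter together and give a 4.0-fold higher number from compound 2 to compound 4 (0.61 log units; beyond the scatter) in this assay. Against the unsubstituted ring the same group gives a 1.6-fold higher number from compound 3 to compound 4 (0.20 log units; within the scatter), so compound 4 does not separate from compound 3 and does not regain the standing of compound 2. Nothing on hand accounts for this result.

The compounds shown leave open whether the ring nitrogen or the longer chain carries the step. A 3-phenylpropyl or a pyridin-3-ylmethyl group at this place would separate the two.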